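Swapping a Dichlorophenyl Ether for a Pyridyl Ether

A few compounds are considered here, and "the series" means these few. Any claim that something is new, unique, unknown or untested is made for them only; others in the source may bear on it.

Measured compounds:
compound 1, `CCc1nc2ccccc2n1CCCCOc1c(Cl)cccc1Cl`, 13 uM
compound 2, `Cc1ccc2nc(C(C)O)n(CCCCOc3ccc(C)c(Cl)c3)c2c1`, 8.6 uM
compound 3, `Clc1nc2ccccc2n1CCCCOc1ccccc1`, "not determined" (no result reported)

In an ADME assay on Vero cells (Chlorocebus sabaeus) for cytotoxicity, read by luminescence, with a stated time of 2 days (on this read-out lower numbers stand for higher toxicity in this test and higher numbers for lower toxicity in this test), compound 1 gives 13 uM. Compound 2 gives 8.6 uM in this assay. These two numbers lie within the usual scatter of each other, so neither compound can be placed above the other; compound 1 simply stands alongside compound 2 among the two values available. For compound 3 the entry in this assay reads "not determined" (no result reported), so it adds nothing to the comparison.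

The compound that follows is compound 4, `CCc1nc2ccccc2n1CCCCOc1ccncc1`. It differs from compound 1 in one place: pyridin-4-yl in place of 2,6-dichlorophenyl on an oxygen on a saturated carbon. Among the compounds with values here, no measured pair in this set shows such a change, so the data give no step from which its size could be read. With only compounds 1 and 2 to go on, both close together in this assay, the expectation rests on the structural change alone.

In this assay compound 4 is estimated at 25 uM, with a range from 10 uM to 60 uM. That estimate means an expected step of a 1.9-fold higher number from compound 1 to compound 4 (0.28 log units; within the scatter), a little beyond the usual scatter toward the less toxic side, though a result within the scatter would not be surprising.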

Compound 4, half-maximal toxic concentration: > 50 uM
Compound 4: no number, only a limit; the forecaster's own chance of this, stated with the estimate: 20%; at least 2.0-fold (0.30 log units) between middle value and limit.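

In this assay, within the data shown here, the position on an oxygen on a saturated carbon now has its first readable change, as no earlier pair of compounds differed in one place. Pyridin-4-yl in place of 2,6-dichlorophenyl gives an at least 3.8-fold higher number from compound 1 to compound 4 (0.58 log units; beyond the scatter), a step beyond the scatter toward lower toxicity in this test, whereas the two earlier numbers could not be placed apart. From the compounds shown here alone, compound 4 reads > 50 uM, which is a limit of the assay and not a number, so the step gives only a smallest size and its full size remains unknown: the limit of > 50 uM in this assay, at which 1 of the 4 values shown sits.

This single pair swaps both the two chlorine atoms and the carbon-only ring for a ring with one nitrogen, so it cannot tell whether losing the chlorines or gaining the nitrogen accounts for the step, and compound 3, which carries a plain phenyl ring on a different core, has no result to help separate them. Also open, going by these compounds, is how a pyrimidine ring or a cyclohexyl group on that same oxygen would read in this assay, and whether the step would hold on a longer chain.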